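This account rests on a few compounds, and the source may have more. Where it says the series, first, only, none or still open, it means among the compounds named here.

Working notes on the series. Among the compounds with values here, the shared core of compound 1 `Cc1nn(C2COC2)cc1Nc1nc(N)c2c(C#N)c(N3CCC[C@H]3C)n(C)c2n1` carries an oxetan-3-yl group on an aromatic nitrogen; in an assay on HEK293 cells for inhibition of Leucine-rich repeat serine/threonine-protein kinase 2 (Homo sapiens), with a stated time of 48 h (on this read-out higher numbers stand for weaker inhibition and lower numbers for stronger inhibition), compound 1 gives 240 nM, the only value of its own in this set, with a further entry that has no single number. Compound 2 `Cc1nn(C2CCOC2)cc1Nc1nc(N)c2c(C#N)c(N3CCC[C@H]3C)n(C)c2n1` has been measured more than once in this assay, and compound 2 gives 140 nM; 260 nM (2 entries); the spread of these entries, (the several entries of compound 2 in this assay, 140 nM; 260 nM (2 entries)), lies within the usual scatter, and the value of compound 1 falls inside the same span, so the two compounds cannot be separated on these numbers.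

Compound 3 `Cc1nn(CC(C)(C)O)cc1Nc1nc(N)c2c(C#N)c(N3CCC[C@H]3C)n(C)c2n1` differs from compound 1 in one place: 2-hydroxy-2-methylpropyl in place of oxetan-3-yl on an aromatic nitrogen. Within the data shown here, no measured step of this kind is available, so the expectation rests on the small range seen so far across compound 1 and compound 2. The step of a 1.0-fold higher number from compound 1 to compound 3 (0.02 log units; within the scatter) is estimated to stay within the scatter, in no clear direction. Compound 3 is expected to give about 250 nM in this assay, with a range from 90 nM to 700 nM.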

Compound 3, half-maximal inhibitory concentration: 280 nM
Beside the measured number, compound 3's estimate is 1.1-fold (0.05 log units) below it; measured number inside the range.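

Replacing oxetan-3-yl with 2-hydroxy-2-methylpropyl on the aromatic nitrogen gives a 1.2-fold higher number from compound 1 to compound 3 (0.07 log units; within the scatter) in this assay. Within the data shown here, the earlier compounds both carried a ring at this place, so this is the first indication that the read-out holds with a group that has no ring and brings a hydrogen-bond donor, though it rests on this one open chain. The step is smaller than the spread of repeat entries for a single compound: the several entries of compound 2 in this assay, 140 nM; 260 nM (2 entries)

Open is how the read-out responds at this nitrogen to an amine, a carboxylic acid, a longer chain or a plain alkyl group such as isopropyl, any of which could show whether the position has a limit that the groups shown do not reach. Also open, going by these compounds, is what the hydroxyl and the two methyl groups of 2-hydroxy-2-methylpropyl each contribute, as this single exchange changes them together with the loss of the ring.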